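The source may hold more compounds than are shown below. What is called first, only, known or untested is meant among the compounds shown, and "the series" means these compounds.

Measured so far:
Compound 1 `O=C(N/N=C\c1ccccn1)c1ccc(-c2nc3ccccc3s2)cc1` gives 10200 nM in an assay on isolated protein for inhibition of Maltase-glucoamylase (Homo sapiens), with a stated time of 15 min; on this read-out lower numbers stand for stronger inhibition and higher numbers for weaker inhibition.
Compound 2 `O=C(N/N=C/c1cccc(O)c1O)c1ccc(-c2nc3ccccc3s2)cc1` gives 11200 nM in this assay.

Compound 2 gives the higher of the two numbers obtained in this assay, but its gap to compound 1 lies within the usual scatter of such measurements, so the two cannot be ranked. Compound 3 `O=C(N/N=C/c1ccccc1O)c1ccc(-c2nc3ccccc3s2)cc1` has not yet been measured. It differs from compound 2 in one place: hydrogen in place of hydroxy on an aromatic carbon. Within the data shown here, no step between measured compounds is available to gauge a change of this kind. Compound 1 at 10200 nM and compound 2 at 11200 nM sit close together, and the change removes only a single hydroxy. The step is therefore expected to stay within the scatter, with no clear direction, as a 1.0-fold lower number from compound 2 to compound 3 (0.01 log units; within the scatter). For compound 3 the expected value in this assay is 11000 nM, within a range from 4000 nM to 30000 nM.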

Compound 3, half-maximal inhibitory concentration: 5550 nM
For compound 3 the middle estimate is 2.0-fold (0.30 log units) above the measured one, within the range that was stated.
By their numbers in this assay, from the lowest: compounds 3, 1 and 2 (each within the scatter of the next).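

In this assay, the change from 2,3-dihydroxyphenyl to 2-hydroxyphenyl gives a 2.0-fold lower number from compound 2 to compound 3 (0.30 log units; within the scatter). This first step at this position shows that removing this hydroxy, which is ortho to a hydroxy group, has no effect that can be told from the scatter. The change of the whole group on the amide-type nitrogen gives a 1.8-fold lower number from compound 1 to compound 3 (0.26 log units; within the scatter), also no readable difference, and nothing available here bears on a cause for either step.

The compounds shown leave open whether a methoxy group or an amine on this aromatic carbon would move the number beyond the scatter. They also leave open what a plain phenyl group, with no hydroxy at all, would give in this assay.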